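The source may hold more compounds than are shown below. What is called first, only, known or untested is meant among the compounds shown, and "the series" means these compounds.

Compound 1 has the structure `CCN(CC)c1cc2[nH]c(C3CCCCC3)nc2cc1NC(=O)OCC(F)(F)F`. In an ADME assay on Vero cells (Chlorocebus sabaeus) for cytotoxicity, read by resazurin assay, with a stated time of 3 days (on this read-out lower numbers stand for stronger inhibition and higher numbers for weaker inhibition), compound 1 gives > 100 ug/mL, which is a limit of the assay and not a number. Compound 2 has the structure `CCCC(C)OC(=O)Nc1cc2nc(C3CCCCC3)[nH]c2cc1N(CC)CC`. In this assay compound 2 gives > 100 ug/mL, again a limit. Compound 3 has the structure `CCN(CC)c1cc2[nH]c(C3CCCCC3)nc2cc1NC(=O)c1ccc(Br)cc1`. In this assay compound 3 gives > 100 ug/mL, also a limit.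

Compound 3 therefore stands at the limit of > 100 ug/mL in this assay, at which 3 of the 3 values shown sit, and nothing separates it from the other two on the numbers shown. Compound 4 has the structure `CCCOCC(=O)Nc1cc2nc(C3CCCCC3)[nH]c2cc1N(CC)CC` and is yet to be measured. Its difference from compound 3 is propoxymethyl in place of 4-bromophenyl on a carbonyl carbon. The steps that touch the carbonyl carbon in the measured set are a step that the two limits leave unreadable from compound 1 to compound 3 and a step that the two limits leave unreadable from compound 2 to compound 3, and the step that the two limits leave unreadable from compound 1 to compound 2 on the oxygen is no more readable. Among the measured compounds shown here, with every measured value sitting at a limit, no step of any size can be read, and no shift beyond the scatter is expected for the change to compound 4. Compound 4 is expected to give 150 ug/mL, with a range from 60 ug/mL to 400 ug/mL. The expected step is a step that the limit leaves unreadable from compound 3 to compound 4.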

Compound 4, half-maximal inhibitory concentration: > 100 ug/mL
Compound 4 was reported as a limit; the forecaster's own chance of this, stated with the estimate: 85%; the middle value lies beyond the limit too.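

Compound 4 reads as a limit and not a number, so no step from compound 1, compound 2 or compound 3 to compound 4 can be read, as all four compounds sit at the same limit: the limit of > 100 ug/mL in this assay, at which 4 of the 4 values shown sit.

The compounds shown leave open what concentration of any of them would inhibit these cells, and whether the groups on the carbonyl carbon change it.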